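A few compounds are considered here, and "the series" means these few. Any claim that something is new, unique, unknown or untested is made for them only; others in the source may bear on it.

Series on a shared core. Compound 1 `CCC(COc1cccc(Cl)c1)OC(=O)NCc1ccccc1` in an assay for inhibition of zeta-carotene desaturase, chloroplastic/chromoplastic (Capsicum annuum), using a Dixon plot, with a stated time of 8 h (on this read-out lower numbers stand for stronger inhibition and higher numbers for weaker inhibition), gives only a limit, > 100000 nM. Compound 2 `CCC(COc1cccc(Cl)c1)OC(=O)N(CC)Cc1ccccc1` gives only a limit in this assay, > 100000 nM. Compound 3 `CCC(COc1cccc(Cl)c1)OC(=O)N(Cc1ccccc1)C(C)=O` likewise gives only a limit in this assay, > 100000 nM. All three values sit at the limit of > 100000 nM in this assay, at which 3 of the 3 values shown sit, so the steps a step that the two limits leave unreadable from compound 1 to compound 2, a step that the two limits leave unreadable from compound 1 to compound 3 and a step that the two limits leave unreadable from compound 2 to compound 3 have no readable size. Compound 4 `CCC(COc1cccc(Cl)c1)OC(=O)N(C=O)Cc1ccccc1` differs from compound 3 by hydrogen in place of methyl on a carbonyl carbon; read one bond further out, acetyl to formyl. The measured steps at the amide-type nitrogen show nothing beyond the limit, so no direction in this assay can be expected. Compound 4 is therefore expected to stay at the limit, estimated at 150000 nM between 50000 nM and 1000000 nM. The expected step from compound 3 to compound 4 is a step that the limit leaves unreadable from compound 3 to compound 4.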

Compound 4, half-maximal inhibitory concentration: > 100000 nM
Compound 4: only a limit was reported; the forecaster's own chance of this, stated with the estimate: 85%; the middle value is on the limit's open side.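

Compound 4 also gives only a limit in this assay, > 100000 nM, so no step from compound 1, compound 2 or compound 3 to compound 4 can be read: the limit of > 100000 nM in this assay, at which 4 of the 4 values shown sit.

The compounds shown leave open whether any change on the shared core gives a readable value in this assay.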